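The compounds below may be only part of what the source reports. "The series", "measured", "known", "first", "only" and "open" are said of these compounds alone.

In an assay on isolated protein for inhibition of protein kinase C theta type (Homo sapiens), read by TR-FRET, with a stated time of 2 h (a lower number here means a stronger inhibitor, a higher number a weaker inhibitor), compound 1 `N#Cc1cnc(NCc2cnccc2C(F)(F)F)cc1N[C@H]1CC[C@@H](O)CC1` gives 100 nM. Compound 2 `CO[C@H]1CC[C@@H](Nc2cc(NCc3cnccc3C(F)(F)F)ncc2C#N)CC1` gives 58 nM in this assay, a change of a 1.7-fold lower number from compound 1 to compound 2 (0.24 log units; within the scatter). Compound 3 `CO[C@H]1CC[C@H](Nc2cc(NCc3cnccc3C(F)(F)F)ncc2C#N)CC1` gives 1100 nM, the highest of the three numbers. The step of a 19-fold higher number from compound 2 to compound 3 (1.28 log units; beyond the scatter) arises because of the fact that compounds 2 and 3 differ only in the configuration as drawn; the step of an 11-fold higher number from compound 1 to compound 3 (1.04 log units; beyond the scatter) is similar in size.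

Compound 4 `CO[C@H]1CC[C@@H](CNc2cc(NCc3cnccc3C(F)(F)F)ncc2C#N)CC1` differs from compound 3 by (4-methoxycyclohexyl)methyl in place of 4-methoxycyclohexyl on a nitrogen on an aromatic ring. Going by the values given here, none of the three measured steps touches the link between the saturated ring and the nitrogen, so no measured step bears directly on this change. The step of a 1.4-fold higher number from compound 3 to compound 4 (0.13 log units; within the scatter) is therefore expected only as a cautious guess, leaning towards a weaker inhibitor. Compound 4 is estimated at 1500 nM, with a range from 300 nM to 8000 nM.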

Compound 4, half-maximal inhibitory concentration: 70 nM
The estimate for compound 4 lay 21-fold (1.33 log units) above the measured number; measured number outside the range, below it.
By their numbers in this assay, from the lowest: compounds 2, 4 and 1 (each within the scatter of the next); then compound 3.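

On a nitrogen on an aromatic ring, (4-methoxycyclohexyl)methyl in place of 4-methoxycyclohexyl has no single size of effect: it gives a 16-fold lower number from compound 3 to compound 4 (1.20 log units; beyond the scatter), but a 1.2-fold higher number from compound 2 to compound 4 (0.08 log units; within the scatter). The step of a 1.4-fold lower number from compound 1 to compound 4 (0.15 log units; within the scatter) likewise stays within the scatter. The two starting points of this one change give such different results, and they are related in this way: the fact that compounds 2 and 3 differ only in the configuration as drawn. Still open, going by these compounds, is how the opposite configuration of compound 4 would compare, and whether a longer chain, such as (4-methoxycyclohexyl)ethyl, would hold the number in this assay.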